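Amide-side chain change on a pyrazole bis-amide

This account rests on a few compounds, and the source may have more. Where it says the series, first, only, none or still open, it means among the compounds named here.

Of the compounds shown here, three have been measured in an ADME assay on MRC5 cells (Homo sapiens) for inhibition, with a stated time of 72 h; a lower number here means that less compound is needed, a higher number that more compound is needed for the effect. Compound 1 `CCc1ccccc1C(=O)Nc1c[nH]nc1C(=O)N[C@H]1CC[C@H](OC)CC1` gives 3400 nM, and compound 3 `CO[C@H]1CC[C@H](NC(=O)c2n[nH]cc2NC(=O)c2ccc(OC(F)F)cc2)CC1` gives 2500 nM. Compound 2 `COc1cccc(OC)c1C(=O)Nc1c[nH]nc1C(=O)N[C@H]1CC[C@H](O)CC1` gives 34000 nM, the highest of the three numbers, beyond the scatter from both others. Compound 4 `COc1cccc(OC)c1C(=O)Nc1c[nH]nc1C(=O)NCCCOC(C)C` has not yet been measured; it differs from compound 2 at one place: 3-isopropoxypropyl in place of 4-hydroxycyclohexyl on an amide-type nitrogen. Among the compounds with values here, no pair of measured compounds differing only at this place exists, so the size of the step is uncertain; a modest move toward a lower number is expected, and the step from compound 2 to compound 4 is estimated as a 1.7-fold lower number from compound 2 to compound 4 (0.23 log units; within the scatter). Compound 4 is therefore expected to give about 20000 nM, with a likely range from 6000 nM to 60000 nM.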

Compound 4, half-maximal effective concentration: > 50000 nM
Compound 4 ended at the assay's limit; the forecaster's own chance of this, stated with the estimate: 15%; middle value at least 2.5-fold (0.39 log units) away from the limit.
By their numbers in this assay, from the lowest: compounds 3 and 1 (each within the scatter of the next); then compound 2. At a limit, above all of these: compound 4.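

In this assay, within the data shown here, the first reading at this amide-type nitrogen shows no move toward a lower number when 3-isopropoxypropyl takes the place of 4-hydroxycyclohexyl, giving an at least 1.4-fold higher number from compound 2 to compound 4 (0.16 log units; that floor lies within the scatter). Compound 4 gives > 50000 nM, which is a limit of the assay and not a number. The step is therefore only a floor, because compound 4 sits at that limit: the limit of > 50000 nM in this assay, at which 1 of the 4 values shown sits.

Whether the ring or the hydroxyl of compound 2 matters more remains unseparated. Also open, as far as these compounds go, is what a 4-aminocyclohexyl group or a carboxylic acid on this nitrogen would give.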